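The source may hold more compounds than are shown below. What is called first, only, known or untested is meant among the compounds shown, and "the series" means these compounds.

Measured compounds:
Compound 1, `Cc1cn([C@H]2C=C[C@@H](COP(=O)(O)OP(=O)(O)OCc3ccc(OC(=O)c4ccc(C(F)(F)F)cc4)cc3)O2)c(=O)[nH]c1=O`: 11.5 h
Compound 2, `CCCCCCCC(=O)Oc1ccc(COP(=O)(O)OP(=O)(O)OC[C@H]2O[C@@H](n3cc(C)c(=O)[nH]c3=O)C[C@@H]2N=[N+]=[N-])cc1`: 1.65 h
Compound 3, `CCCCCCCC(=O)Oc1ccc(COP(=O)(O)OP(=O)(O)OC[C@@H]2C=C[C@H](n3cc(C)c(=O)[nH]c3=O)O2)cc1`: 1.65 h

Three compounds have been run in an ADME assay on CCRF-CEM cells (Homo sapiens) for metabolic stability, read by HPLC, at 37 degrees C (on this read-out lower numbers stand for a shorter-lived compound and higher numbers for a longer-lived compound), and a fourth, compound 4, `Cc1cn([C@H]2C[C@H](N=[N+]=[N-])[C@@H](COP(=O)(O)OP(=O)(O)OCc3ccc(OC(=O)c4ccc(C(F)(F)F)cc4)cc3)O2)c(=O)[nH]c1=O`, awaits its turn. Compound 1 stands apart from the other two: in this assay compound 1 gives 11.5 h, whereas compound 2 gives 1.65 h and compound 3 gives 1.65 h, the two latter numbers level with each other at the digits recorded.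

Compound 3 and compound 1 differ in a single place, (4-(trifluoromethyl)phenyl in place of heptyl on a carbonyl carbon), and that change made the step of a 7.0-fold higher number from compound 3 to compound 1 (0.84 log units; beyond the scatter). Compound 4 is built from compound 2 by the same change, (4-(trifluoromethyl)phenyl in place of heptyl on a carbonyl carbon), at the same place. The cores of compound 2 and compound 3 differ from one another, but that difference is not broken down here.

Since compound 2 matches compound 3 in this assay at the digits recorded, and the change has so far been observed only once, the expectation for compound 4 rests on that single pair. Among the compounds with values here, compound 4 is therefore expected to show a step of a 6.1-fold higher number from compound 2 to compound 4 (0.78 log units; beyond the scatter), of the same size as the one seen from compound 3 to compound 1 because of a 7.0-fold higher number from compound 3 to compound 1 (0.84 log units; beyond the scatter). The estimate for compound 4 in this assay is 10 h, within a range from 4 h to 25 h.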

Compound 4, half-life: 3.83 h
Beside the measured number, compound 4's estimate is 2.6-fold (0.42 log units) above it; the whole stated range lies above it.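

In this assay, the swap of heptyl for 4-(trifluoromethyl)phenyl on the carbonyl carbon again went upward, giving a 2.3-fold higher number from compound 2 to compound 4 (0.37 log units; beyond the scatter), so the direction of the change held on both cores shown. The size of the step did not carry over, and the two steps stand clearly apart: the same change on two cores in this assay, a 7.0-fold higher number (0.84 log units; beyond the scatter) from compound 3 to compound 1 and a 2.3-fold higher number (0.37 log units; beyond the scatter) from compound 2 to compound 4, 3.0-fold (0.48 log units) apart, beyond the scatter of two such steps With only these two pairs, the series shows that the direction repeated while the size depended on the core it was placed on, but it does not show which feature of the cores sets that size, nor how large the step would be on a third core.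

The compounds shown leave open whether the same upward direction would appear with other groups on the carbonyl carbon, such as a longer chain than heptyl, a shorter chain such as propyl, or a phenyl ring carrying a nitrile or a methoxy group in place of trifluoromethyl. They also leave open whether a core carrying an amine or a carboxylic acid would give a step closer to the larger or the smaller of the two seen here.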